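One Small Change Repeated on a Different Core

The source may report more compounds than this note shows. Statements on the series, on what has been measured and on what is new or still open speak of the compounds shown alone.

Compound 1 `O=C(O)c1ccc(NC(=O)c2ccc(-c3nn[nH]n3)cc2)cc1` and compound 2 `NC(=O)c1ccc(NC(=O)c2ccc(-c3nn[nH]n3)cc2)cc1` share a core and differ at one point only: hydroxy in place of amino on a carbonyl carbon. In a functional assay on the whole organism with Rattus norvegicus as the target, at a dose of 25 mg/kg by the intravenous route (a higher number here means that more compound is needed for the effect, a lower number that less compound is needed), compound 2 gives 2 mg/kg, and compound 1 gives 2.3 mg/kg; the step of a 1.2-fold higher number from compound 2 to compound 1 (0.06 log units; within the scatter). Compound 3 `N#Cc1ccc(C(=O)Nc2cc(C(N)=O)cc(C(=O)O)c2)cc1` is built on a different core; the difference between the two cores is not broken down here. In this assay compound 3 gives 5.7 mg/kg. Compound 4 `N#Cc1ccc(C(=O)Nc2cc(C(=O)O)cc(C(=O)O)c2)cc1` has not yet been measured; it differs from compound 3 by the same change, (hydroxy in place of amino on a carbonyl carbon), at the same kind of place. The earlier step of a 1.2-fold higher number from compound 2 to compound 1 (0.06 log units; within the scatter) stayed within the scatter. On that basis a similarly small step is expected, a 1.1-fold higher number from compound 3 to compound 4 (0.06 log units; within the scatter). Compound 4 is therefore estimated at 6.5 mg/kg in this assay, with a likely range from 3.5 mg/kg to 12 mg/kg.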

Compound 4, dose for 50% inhibition: 1.7 mg/kg
Beside the measured number, compound 4's estimate is 3.8-fold (0.58 log units) above it; the whole stated range lies above it.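

On the core of compound 3, putting carboxy in place of carbamoyl gives a 3.4-fold lower number from compound 3 to compound 4 (0.53 log units; beyond the scatter) in this assay, so less of compound 4 is needed for the effect. For the compounds shown here, the change therefore does not carry over with the same size from one core to the other: the same change on two cores in this assay, a 1.2-fold higher number (0.06 log units; within the scatter) from compound 2 to compound 1 and a 3.4-fold lower number (0.53 log units; beyond the scatter) from compound 3 to compound 4, 3.9-fold (0.59 log units) apart, beyond the scatter of two such steps With only one pair on each core, this shows that the step can differ between these two cores, but not which difference between the cores matters or what the change would do on a third core.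

The compounds shown leave open how a methyl ester on the same carbonyl carbon would compare with carboxy and carbamoyl on either core.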